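The source may hold more compounds than are shown below. What is called first, only, known or untested is meant among the compounds shown, and "the series" means these compounds.

Compound 2 `CCOC(=O)c1cnn(-c2nc(-c3ccc(OC)cc3)c(C#N)c(=O)n2C)c1N` gives 68 ug/mL in a functional assay on microsomes for inhibition, with a stated time of 1 h (a lower number here means a stronger inhibitor, a higher number a weaker inhibitor), the second highest of the three numbers recorded. Compound 1 `CCOC(=O)c1cnn(-c2nc(-c3ccccc3Cl)c(C#N)c(=O)n2C)c1N` gives 102 ug/mL and compound 3 `Cn1c(NN)nc(-c2ccccc2F)c(C#N)c1=O` gives 43 ug/mL in this assay; both sit within the scatter of compound 2. For the measured compounds named here, the only step between measured compounds that differ in one place, a 1.5-fold lower number from compound 1 to compound 2 (0.18 log units; within the scatter), stays within the scatter. Compound 4 `CCOC(=O)c1cnn(-c2nc(-c3cccc(O)c3O)c(C#N)c(=O)n2C)c1N` differs from compound 2 by 2,3-dihydroxyphenyl in place of 4-methoxyphenyl on an aromatic carbon. Going by the values given here, no measured step tests a dihydroxyphenyl at that aromatic carbon, and the one swap of the aryl group recorded, a 1.5-fold lower number from compound 1 to compound 2 (0.18 log units; within the scatter), moved the number little, so no step beyond the scatter is expected here. Compound 4 is therefore estimated at 60 ug/mL in this assay, with a range from 25 ug/mL to 150 ug/mL, which is expected to amount to a 1.1-fold lower number from compound 2 to compound 4 (0.05 log units; within the scatter).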

Compound 4, half-maximal inhibitory concentration: 49 ug/mL
Compound 4: the middle estimate sits 1.2-fold (0.09 log units) above what was measured; measured number inside the range.
By their numbers in this assay, from the lowest: compounds 3, 4, 2 and 1 (each within the scatter of the next, the first and the last beyond it).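

At this aromatic carbon, ortho to a cyano group, the hydrogen-bond donors of 2,3-dihydroxyphenyl are tolerated in this assay: replacing 4-methoxyphenyl gives a 1.4-fold lower number from compound 2 to compound 4 (0.14 log units; within the scatter). For the compounds shown here, replacing 2-chlorophenyl gives a 2.1-fold lower number from compound 1 to compound 4 (0.32 log units; beyond the scatter), the first aryl change at this position to pass the scatter, though only modestly. No supporting data bear on the origin of either step. On these data alone, whether a phenyl with a single hydroxyl reads like the pair remains open. So does the reading in this assay for a phenyl carrying an amine or a carboxylic acid.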